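The compounds below may be only part of what the source reports. "The series", "measured", "known", "first", "only" and "open" are said of these compounds alone.

Measured so far:
compound 1 `CCCCC[Se]c1nc(NCc2ccc(SC)cc2)c2ccccc2n1`: 40400 nM
compound 2 `Sc1nc(NCc2ccccc2)c2ccccc2n1`: 15200 nM

In a functional assay on HTB-54 cells (Homo sapiens) for cytotoxicity, read by MTT assay, with a stated time of 72 h (on this read-out lower numbers stand for stronger inhibition of growth and higher numbers for weaker inhibition of growth), compound 2 holds the lower of the two numbers; compound 1 stands above it, beyond the scatter. Compound 3 `CCCCC[Se]c1nc(NCc2ccccc2)c2ccccc2n1` differs from compound 2 by a group of 6 heavy atoms (5 carbon, 1 selenium; no ring) in place of one sulfur atom, on an aromatic carbon. Among the compounds with values here, no step between measured compounds isolates this change, so the expectation leans on compound 1, which carries the same entering group and gives 40400 nM in this assay; on that basis a step toward weaker inhibition is expected, a 2.0-fold higher number from compound 2 to compound 3 (0.30 log units; within the scatter). For compound 3 the estimate is 30000 nM, range 12000 nM to 80000 nM.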

Compound 3, concentration for 50% growth inhibition: 37700 nM
For compound 3 the middle estimate is 1.3-fold (0.10 log units) below the measured one; measured number inside the range.
By their numbers in this assay, from the lowest: compound 2; then compounds 3 and 1 (each within the scatter of the next).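

In this assay the group of 6 heavy atoms in place of sulfanyl, on the aromatic carbon between two ring nitrogen atoms, gives a 2.5-fold higher number from compound 2 to compound 3 (0.39 log units; beyond the scatter) and so moves toward weaker inhibition of growth. Hydrogen in place of methylsulfanyl on an aromatic carbon gives a 1.1-fold lower number from compound 1 to compound 3 (0.03 log units; within the scatter) and so leaves no readable difference with the selenium-bearing group in place. Nothing measured here explains either step.

The compounds shown do not separate the selenium atom from the chain attached to it. A pentylsulfanyl group or an amine at this position would address that question.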